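This account rests on a few compounds, and the source may have more. Where it says the series, first, only, none or still open, it means among the compounds named here.

In a physicochemical assay for lipophilicity (on this read-out lower numbers stand for lower lipophilicity and higher numbers for higher lipophilicity), compound 1 `O=C1NC(=O)C(Cc2ccc(OCC3CCCCC3)cc2)S1` gives 3.94 and compound 2 `O=C1N=C(O)S/C1=C\c1ccc(OCC2CCCCC2)cc1` gives 3.66, two values within the usual scatter of each other. Among the compounds with values here, compound 1 therefore stands level with the only other measured compound. Compound 3 `CCOc1ccc(CC2SC(=O)NC2=O)cc1` is still unmeasured. Its structure departs from compound 1 by methyl in place of cyclohexyl on a saturated chain carbon bound to an oxygen on an aromatic ring, which, cut one bond further out, reads cyclohexylmethyl to ethyl. Within the data shown here, the series holds no measured step for this change, so the expectation rests on the structural change and on compound 1 at 3.94. The expected step, well beyond the scatter and towards lower numbers, is a number 1.84 log units lower from compound 1 to compound 3 (beyond the scatter). For compound 3 the estimated value in this assay is 2.1, with an expected range of 1.6 to 2.6.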

Compound 3, partition coefficient: 2.43
Compound 3: middle estimate off by 0.33 log units, on the low side; the measured number falls inside the stated range.
By their numbers in this assay, from the lowest: compound 3; then compounds 2 and 1 (each within the scatter of the next).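

In this assay, within the data shown here, methyl in place of cyclohexyl on a saturated chain carbon bound to an oxygen on an aromatic ring gives a number 1.51 log units lower from compound 1 to compound 3 (beyond the scatter), the only measured step at this position. Compounds 1 and 2 both carry cyclohexylmethyl, so they could not show that this read-out responds to the group at this place, or that the response to this change is large. No measurement on hand accounts for the size of the step.

From the compounds shown here alone, whether the step follows the loss of the ring or the shorter chain remains open, and an open-chain hexyl or a phenyl at this place would bear on that question. Also open, going by these compounds, are how an amine or a carboxylic acid at this place would read, and whether the same change gives a similar step on the core of compound 2.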